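Capping the Ring Nitrogen of Compound 3

The source may report more compounds than this note shows. Statements on the series, on what has been measured and on what is new or still open speak of the compounds shown alone.

Three compounds share a core in which a triazole carries a dithiocarbamate linked to a six-membered ring with two nitrogens. In a functional assay on ECa-109 cells (Homo sapiens) for inhibition, read by MTT assay, with a stated time of 72 h (on this read-out lower numbers stand for stronger inhibition and higher numbers for weaker inhibition), compound 1 `COc1ccc(-n2cc(CSC(=S)N3CCN(C(=O)OC(C)(C)C)CC3)nn2)cc1` reaches only the limit of the assay and gives > 128000 nM, not a number. Within the data shown here, compound 2 `Cc1ccc(Cn2cc(CSC(=S)N3CCN(C(=O)OC(C)(C)C)CC3)nn2)cc1` gives 47900 nM in this assay, and the change an at least 2.6-fold lower number from compound 1 to compound 2 (0.42 log units; beyond the scatter) is the only measured step here. Compound 3 `S=C(SCc1cn(Cc2ccc(Cl)c(Cl)c2)nn1)N1CCNCC1` also sits at the limit of this assay, giving > 128000 nM, so no number stands for it; only that 2 of the 3 values shown rest at this same limit, (the limit of > 128000 nM in this assay, at which 2 of the 3 values shown sit), can be said.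

Compound 4 `CC(C)(C)OC(=O)N1CCN(C(=S)SCc2cn(Cc3ccc(Cl)c(Cl)c3)nn2)CC1` differs from compound 3 by tert-butoxycarbonyl in place of hydrogen on an amine nitrogen in a ring. Among the measured compounds shown here, no measured step touches this change: the single step from compound 1 to compound 2 alters the group on the aromatic nitrogen, not the ring amine. Without a direct comparison, compound 4 is estimated at 70000 nM, within 25000 nM to 200000 nM, which would mean an expected step of an at least 1.8-fold lower number from compound 3 to compound 4 (0.26 log units; that floor lies within the scatter) from the limit of compound 3.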

Compound 4, half-maximal inhibitory concentration: > 128000 nM
Compound 4: no number, only a limit; the forecaster's own chance of this, stated with the estimate: 40%; middle value at least 1.8-fold (0.26 log units) away from the limit.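

In this assay compound 4 gives > 128000 nM, a limit and not a number, so its steps from compound 3 and from compound 1 cannot be read. Among these compounds, the one readable step lies elsewhere: with tert-butoxycarbonyl kept on the ring nitrogen, 3,4-dichlorophenyl in place of 4-methylphenyl gives an at least 2.6-fold higher number from compound 2 to compound 4 (0.42 log units; beyond the scatter). With the 3,4-dichlorobenzyl group on the aromatic nitrogen, neither hydrogen nor tert-butoxycarbonyl on the ring nitrogen gives a readable number, and most of the series now rests at one value: the limit of > 128000 nM in this assay, at which 3 of the 4 values shown sit.

Going by these compounds, it remains open whether another group on this ring nitrogen, such as acetyl or methyl, would give a number that can be read. Also open, on these data alone, is how the free amine would read with 4-methylbenzyl on the aromatic nitrogen.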